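The source may report more compounds than this note shows. Statements on the series, on what has been measured and on what is new or still open speak of the compounds shown alone.

In a functional assay on Bel-7402 cells (Homo sapiens) for inhibition, read by MTT assay, with a stated time of 24 h, tested at 0.1 ug/mL (a lower number here means less inhibition of growth, a higher number more inhibition of growth at the concentration tested), compound 1 (`O=C(CCCCC(S)CCS)Nc1ccc(F)cc1`) reads "not active" (no number reported) and carries no number, while compound 2 (`Cc1cccc(NC(=O)CCCCC(S)CCS)c1`) gives 10.1% as the only figure so far. Compound 3 (`COc1ccc(NC(=O)CCCCC(S)CCS)cc1`) differs from compound 1 by one change, methoxy in place of fluoro on an aromatic carbon (methoxy in place of fluoro on an aromatic carbon, para to a large group). Among the compounds with values here, no measured pair shows this change, and with compound 2 at 10.1% as the sole reference, the step expected in this assay is none beyond the scatter. Compound 3 is estimated at 8% with an expected range from 0% to 20% in this series.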

Compound 3, percent growth inhibition at one concentration: 5.35%
Compound 3: the middle estimate sits 2.7 percentage points above what was measured, and the stated range covers the measured number.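

In this assay, within the data shown here, compound 1 carries no number, so no step from it to compound 3 can be read. As far as these compounds go, the effect of methoxy in place of fluoro on growth inhibition stays open, and no measured evidence bears on this result.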